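A few compounds are considered here, and "the series" means these few. Any claim that something is new, unique, unknown or untested is made for them only; others in the source may bear on it.

Compound 1, `O=C(/C=C\Nc1ccc2cc[nH]c2c1)c1nc(-c2ccc(C(F)(F)F)cc2)n2ccccc12`, shows in a functional assay on A549 cells (Homo sapiens) for cytotoxicity, read by MTT assay, with a stated time of 48 h (on this read-out higher numbers stand for weaker inhibition and lower numbers for stronger inhibition), only the assay limit, > 30000 nM. Compound 2, `COc1ccc(-c2nc(C(=O)/C=C\Nc3ccc(Cl)cc3)c3ccccn23)cc1`, has no result: "not determined" (no result reported). Compound 3, `O=C(/C=C\Nc1ccc2[nH]ccc2c1)c1nc(-c2ccc(C(F)(F)F)cc2)n2ccccc12`, gives 5190 nM.

Within the data shown here, compound 3 thus stands as the only single number among the three; the one other value is a limit and the third entry is empty. Among the measured compounds shown here, the only measured step, an at least 5.7-fold lower number from compound 1 to compound 3 (0.76 log units; beyond the scatter), concerns a different exchange. Compound 4, `O=C(/C=C\Nc1ccc(Cl)cc1)c1nc(-c2ccc(C(F)(F)F)cc2)n2ccccc12`, differs from compound 3 by 4-chlorophenyl in place of 1H-indol-5-yl on an amine nitrogen. For the measured compounds named here, no measured step bears on this exchange, and compound 2, the other compound carrying a (4-chlorophenyl)amino group, has no result. The expected step of a 1.5-fold higher number from compound 3 to compound 4 (0.19 log units; within the scatter) is therefore none beyond the scatter, with wide uncertainty. Compound 4 is estimated at 8000 nM, between 2000 nM and 30000 nM.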

Compound 4, half-maximal inhibitory concentration: 18500 nM
Compound 4: the middle estimate sits 2.3-fold (0.36 log units) below what was measured; measured number inside the range.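

In this assay, the group on the amine nitrogen also matters when the indole gives way to a single aromatic ring, not only between the two indolyl isomers: a 3.6-fold higher number from compound 3 to compound 4 (0.55 log units; beyond the scatter). The other new step reads an at least 1.6-fold lower number from compound 1 to compound 4 (0.20 log units; that floor lies within the scatter), so it sets no order beyond the scatter. That step rests on a limit, the only entry for compound 1: the limit of > 30000 nM in this assay, at which 1 of the 4 values shown sits.

The compounds shown leave open how a plain phenyl or a 4-aminophenyl group would read on this nitrogen. They also leave open whether 1H-indol-5-yl keeps its place when the trifluoromethyl group gives way to a methoxy group.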